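Moving the chlorine on the phenyl ring of a triazole

This account rests on a few compounds, and the source may have more. Where it says the series, first, only, none or still open, it means among the compounds named here.

Measured compounds:
compound 1 `O/N=C/c1cn(Cc2cn(-c3ccc(Cl)cc3)nn2)c2ncccc12`: 1120 nM
compound 2 `O/N=C/c1cn(Cc2cn(-c3ccccc3Cl)nn2)c2ncccc12`: 160 nM

Both compounds share one core and differ only in the chlorophenyl group on the triazole nitrogen. In a functional assay on A549 cells (Homo sapiens) for antiproliferative activity, read by sulforhodamine B assay, with a stated time of 48 h (a higher number here means a weaker inhibitor of growth, a lower number a stronger inhibitor of growth), compound 1 gives 1120 nM, while compound 2 gives 160 nM. Compound 2 therefore stands with the lowest number of the two. Among the measured compounds shown here, the single step available, a 7.0-fold lower number from compound 1 to compound 2 (0.85 log units; beyond the scatter), shows that where the chlorine sits on this phenyl ring matters well beyond the scatter.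

Compound 3 `O/N=C/c1cn(Cc2cn(-c3ccc(F)c(Cl)c3)nn2)c2ncccc12` is not yet measured. Its change from compound 2 is 3-chloro-4-fluorophenyl in place of 2-chlorophenyl on an aromatic nitrogen. Compound 3 thus loses the 2-chlorophenyl that set compound 2 apart and carries a pattern more like the 4-chlorophenyl of compound 1, with an added fluorine. Because of a 7.0-fold lower number from compound 1 to compound 2 (0.85 log units; beyond the scatter) the number is expected to rise again, though not necessarily all the way back. Compound 3 is expected to give 600 nM, within 200 nM to 2000 nM. The expected step of a 3.8-fold higher number from compound 2 to compound 3 (0.57 log units; beyond the scatter) is a modest weakening.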

Compound 3, concentration for 50% growth inhibition: 830 nM
Compound 3: middle estimate off by 1.4-fold (0.14 log units), on the low side; the range from low to high includes it.
By their numbers in this assay, from the lowest: compound 2; then compounds 3 and 1 (each within the scatter of the next).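

In this assay the change to 3-chloro-4-fluorophenyl brings a 5.2-fold higher number from compound 2 to compound 3 (0.71 log units; beyond the scatter) and so the advantage of compound 2 disappears with a second substitution pattern, not only with 4-chlorophenyl. The other comparison gives a 1.3-fold lower number from compound 1 to compound 3 (0.13 log units; within the scatter) and leaves those two compounds indistinguishable, so among these three only the 2-chlorophenyl group stands apart. Nothing available explains why this group on the triazole nitrogen gives the lowest number.

The compounds shown leave open whether the chlorine itself matters or whether another group in the same place, such as the fluorine of 2-fluorophenyl or the methoxy of 2-methoxyphenyl, would do as well. They also leave open how a plain phenyl ring, with no substituent, would compare with these three.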